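The source may hold more compounds than are shown below. What is called first, only, known or untested is meant among the compounds shown, and "the series" means these compounds.

In an in vitro functional assay on cells for agonist activity at Bombesin receptor subtype-3 (Homo sapiens), read by luminescence and calcium flux (on this read-out lower numbers stand for an effect already at smaller amounts and higher numbers for an effect only at larger amounts of compound), compound 3 `O=C(O)c1ccccc1-c1ccc(CCc2ncc(Cc3cccc(F)c3)[nH]2)cc1` gives 159 nM, the lowest of the three numbers measured. Compound 2 `Cc1cccc(Cc2cnc(CCc3ccc(-c4ccccc4C(=O)O)cc3)[nH]2)c1` gives 4310 nM and compound 1 `O=C(O)c1ccccc1-c1ccc(CCc2ncc(-c3ccccc3)[nH]2)cc1` gives 4950 nM; the step of a 1.1-fold lower number from compound 1 to compound 2 (0.06 log units; within the scatter) stays within the scatter, whereas a 31-fold lower number from compound 1 to compound 3 (1.49 log units; beyond the scatter) and a 27-fold lower number from compound 2 to compound 3 (1.43 log units; beyond the scatter) are large. Compound 4 `O=C(O)c1ccccc1-c1ccc(CCc2ncc(Cc3ccc(Cl)cc3)[nH]2)cc1` differs from compound 3 in one place: 4-chlorophenyl in place of 3-fluorophenyl on a saturated chain carbon bound to an aromatic carbon. The measured steps bear on this only indirectly. For the measured compounds named here, the step of a 27-fold lower number from compound 2 to compound 3 (1.43 log units; beyond the scatter) shows that exchanging a single small group on the benzyl can move this assay a long way, but no measured pair exchanges a 3-fluorobenzyl for a 4-chlorobenzyl, so the direction is open. Compound 4 is therefore expected, with wide uncertainty, to give 400 nM, between 100 nM and 2000 nM, an expected step of a 2.5-fold higher number from compound 3 to compound 4 (0.40 log units; beyond the scatter).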

Compound 4, half-maximal effective concentration: 2290 nM
Estimate against measurement, compound 4: 5.7-fold (0.76 log units) below; measured number above the stated range.
By their numbers in this assay, from the lowest: compound 3; then compounds 4, 2 and 1 (each within the scatter of the next, the first and the last beyond it).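

Exchanging 3-fluorobenzyl for 4-chlorobenzyl at this position is itself a large change (a 14-fold higher number from compound 3 to compound 4 (1.16 log units; beyond the scatter)), so the low number of compound 3 does not carry over to this other halogen-bearing benzyl in this assay. The 4-chlorobenzyl stays within the scatter of the 3-methylbenzyl (a 1.9-fold lower number from compound 2 to compound 4 (0.27 log units; within the scatter)) and lies only modestly apart from the phenyl (a 2.2-fold lower number from compound 1 to compound 4 (0.33 log units; beyond the scatter)), which leaves compound 3 as the only clear outlier here. Nothing available explains this gap. As far as these compounds go, whether the low number belongs to the fluorine itself or to where it sits stays open, as does how an unsubstituted benzyl, a methoxybenzyl or a cyanobenzyl would read.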